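Halogen swap at the distal aryl ring of the triazole series

The source may hold more compounds than are shown below. What is called first, only, known or untested is meant among the compounds shown, and "the series" means these compounds.

Among the compounds with values here, compound 2 `Oc1cc(C(F)(F)F)ccc1-c1nc(-c2ccccc2O)n(-c2ccc(Cl)cc2)n1` gives 87.3% in a functional assay on PC-12 cells (Rattus norvegicus) for cytotoxicity, read by MTT assay, with stated times of 2 h and 24 h, tested at 5 uM (on this read-out lower numbers stand for a weaker effect and higher numbers for a stronger effect at the one concentration tested), the lower of the two numbers so far, though its neighbour compound 1 `CCc1ccc(-n2nc(-c3ccc(C(F)(F)F)cc3O)nc2-c2ccccc2O)cc1` at 95.4% lies within the scatter of it. Compound 3 `Oc1cc(C(F)(F)F)ccc1-c1nc(-c2ccccc2O)n(-c2ccc(I)cc2)n1` differs by iodo in place of chloro on an aromatic carbon. Within the data shown here, the only step at hand, a number 8.1 percentage points lower from compound 1 to compound 2 (within the scatter), concerns a different exchange at the same aromatic carbon and stayed within the scatter; no halogen-to-halogen step is available. Accordingly, compound 3 is expected to show a number 1.3 percentage points lower from compound 2 to compound 3 (within the scatter), no movement beyond the scatter. The estimate for compound 3 is 86%, with a range from 72% to 98%.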

Compound 3, a percentage reported as activity, at one concentration (the size of the read-out at that concentration, not a potency): 94.4%
The estimate for compound 3 lay 8.4 percentage points below the measured number, and the stated range covers the measured number.
By their numbers in this assay, from the lowest: compounds 2, 3 and 1 (each within the scatter of the next).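

In this assay, within the data shown here, the first halogen-to-halogen exchange at this aromatic carbon gives a number 7.1 percentage points higher from compound 2 to compound 3 (within the scatter) and sets beside it a number 1 percentage points lower from compound 1 to compound 3 (within the scatter) for iodo in place of ethyl. With the earlier step, all three pairs now lie within the scatter, so this read-out does not separate ethyl, chloro and iodo at this carbon. No measurement bearing on a cause for these numbers is at hand.

Open, as far as these compounds go, is whether an amine or a carboxylic acid at this carbon would move the number beyond the scatter. From the compounds shown here alone, a longer chain than ethyl also remains open.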